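Sulfone series: metabolic stability working notes

The source may report more compounds than this note shows. Statements on the series, on what has been measured and on what is new or still open speak of the compounds shown alone.

Three sulfones have been measured in an ADME assay on microsomes from liver (Homo sapiens) for metabolic stability, tested at 2.5 uM; on this read-out lower numbers stand for slow clearance and higher numbers for fast clearance. Compound 1 `O=S(=O)(c1ccc(F)cc1)c1cnc2cc(Cl)c(F)cc2c1-c1ccc(Cl)cc1` gives 0.01 mL/min. Compound 2 `O=S(=O)(c1ccc(F)cc1)c1cnc2cc(F)c(Cl)cc2c1-c1ccc(Cl)cc1` gives 0.01 mL/min. Compound 3 `N#Cc1ccc2c(-c3ccc(Cl)cc3)c(S(=O)(=O)c3ccc(F)cc3)cnc2c1` gives 0.01 mL/min, level with compounds 1 and 2 at the digits shown; its nearest neighbour is compound 1 and its furthest is compound 2, in both cases without change at those digits, so the three readings sit within the scatter of one another. Among the compounds with values here, no step between measured compounds is recorded.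

Compound 4 `O=S(=O)(c1ccc(F)cc1)c1cnc2cc(Cl)ccc2c1-c1ccc(Cl)cc1` has not yet been measured in this assay. It differs from compound 3 by chloro in place of cyano on an aromatic carbon. Within the data shown here, the step of no change at the digits printed from compound 3 to compound 4 (within the scatter) is expected to stay within the scatter, since nothing measured so far has moved beyond it. For compound 4 the expected value in this assay is 0.01 mL/min, with a range from 0.005 mL/min to 0.03 mL/min.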

Compound 4, intrinsic clearance in a liver preparation (reported as CLH), per the amount of preparation that the assay uses: 0.21 mL/min
The estimate for compound 4 lay 21-fold (1.32 log units) below the measured number; measured number above the stated range.
By their numbers in this assay, from the lowest: compounds 1, 2 and 3 (each within the scatter of the next); then compound 4.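

In this assay the flat picture ends: chloro in place of cyano on an aromatic carbon gives a 21-fold higher number from compound 3 to compound 4 (1.32 log units; beyond the scatter) and so this place can move the read-out beyond the scatter. Hydrogen in place of fluoro on an aromatic carbon gives a 21-fold higher number from compound 1 to compound 4 (1.32 log units; beyond the scatter) and so a second single change on the core does the same. Nothing at hand explains either step.

Open, from the compounds shown here alone, is whether an amine, a methoxy group or a carboxylic acid in place of the cyano would keep the number low. Also open, going by these compounds, is whether either step carries over to cores with other substituents.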